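Solubility notes: amide replaces ethyl on the piperidine nitrogen

The compounds below may be only part of what the source reports. "The series", "measured", "known", "first", "only" and "open" are said of these compounds alone.

Measured so far in a physicochemical assay for solubility, at pH 7.4; on this read-out lower numbers stand for lower solubility and higher numbers for higher solubility:
Compound 1, `C=CC(=O)Nc1ccc(F)c(-n2c(-c3nc(-c4cnn(C5CCN(C)CC5)c4)cnc3N)nc3ccccc32)c1`, gives only a limit, < 10000 nM.
Compound 2, `C=CC(=O)Nc1ccccc1Cn1c(-c2nc(-c3cnn(C4CCN(C)CC4)c3)cnc2N)nc2ccccc21`, gives 35000 nM.
Compound 3, `C=CC(=O)Nc1cccc(-n2c(-c3nc(-c4cnn(C5CCN(CC)CC5)c4)cnc3N)nc3ccccc32)c1`, gives only a limit, < 10000 nM.

Compound 3 is not placed by a number in this assay; its value is a limit of the assay, and it shares that limit with one other value in the set, as stated in the limit of < 10000 nM in this assay, at which 2 of the 3 values shown sit. For the measured compounds named here, the one fully measured step, an at least 3.5-fold higher number from compound 1 to compound 2 (0.54 log units; beyond the scatter), lies beyond the scatter and moves away from the limit toward a measurable number. That step changes the substituent on the aromatic nitrogen of the shared core and says nothing about the piperidine nitrogen.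

Compound 4, `C=CC(=O)Nc1cccc(-n2c(-c3nc(-c4cnn(C5CCN(C(=O)CO)CC5)c4)cnc3N)nc3ccccc32)c1`, differs from compound 3 only at that ring amine: (hydroxymethyl)carbonyl in place of ethyl on an amine nitrogen in a ring. Going by the values given here, no measured step touches this position, so the expectation for this assay rests on compound 3 sitting at the limit. Compound 4 is expected to stay close to that limit; the step that the limit leaves unreadable from compound 3 to compound 4 is an estimate with no direction supported beyond the scatter. The estimated value for compound 4 is 8000 nM, with a range from 2500 nM to 25000 nM.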

Compound 4, solubility: < 10000 nM
Compound 4 was reported as a limit; the forecaster's own chance of this, stated with the estimate: 65%; the middle value is on the limit's open side.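

Compound 4 gives < 10000 nM in this assay, a limit of the assay. For the compounds shown here, compound 3 also gives a limit, so no step from compound 3 to compound 4 can be read. The compounds shown leave open whether (hydroxymethyl)carbonyl in place of ethyl on the ring amine changes the number at all, with most of the series at one value: the limit of < 10000 nM in this assay, at which 3 of the 4 values shown sit.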